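The source may report more compounds than this note shows. Statements on the series, on what has been measured and on what is new or still open speak of the compounds shown alone.

Two compounds share a core built from a pyrazole-linked aryl group and an aminophenyl enone, and differ only in how many methoxy groups decorate the aryl ring. Compound 1 `COc1ccc(-c2cc(/C=C/C(=O)c3ccc(N)cc3)[nH]n2)cc1` carries a single methoxy group. Compound 2 `COc1cc(-c2cc(/C=C/C(=O)c3ccc(N)cc3)[nH]n2)cc(OC)c1OC` carries three. In a functional assay on SF-539 cells (Homo sapiens) for inhibition, read by sulforhodamine B assay, with a stated time of 48 h (a lower number here means a stronger inhibitor of growth, a higher number a weaker inhibitor of growth), compound 1 gives 1470 nM, and in the same test compound 2 gives 1300 nM. Of these two numbers, compound 2 holds the lower one, but its nearest neighbour, compound 1, sits only a little higher, a gap that falls within the scatter of repeated measurements, so the two cannot be told apart on this evidence.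

Compound 3 `COc1ccc(-c2cc(/C=C/C(=O)c3ccc(N)cc3)[nH]n2)cc1OC` has not yet been measured. It differs from compound 2 by hydrogen in place of methoxy on an aromatic carbon, in other words hydrogen in place of methoxy on an aromatic carbon. Among the measured compounds shown here, no step between measured compounds isolates this change, but since compound 2 with 1300 nM and compound 1 with 1470 nM sit within the scatter of each other across a larger change in methoxy count, the step from compound 2 to compound 3 in this assay is expected to be small, in no clear direction and probably not beyond the scatter, as a 1.1-fold higher number from compound 2 to compound 3 (0.03 log units; within the scatter) expresses. Compound 3 is therefore estimated at 1400 nM, with a plausible range from 700 nM to 2800 nM.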

Compound 3, concentration for 50% growth inhibition: 1730 nM
Compound 3: middle estimate off by 1.2-fold (0.09 log units), on the low side; measured number inside the range.
By their numbers in this assay, from the lowest: compounds 2, 1 and 3 (each within the scatter of the next).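

In this assay, hydrogen in place of methoxy on this aromatic carbon, which is ortho to a methoxy group and meta to a large group, gives a 1.3-fold higher number from compound 2 to compound 3 (0.12 log units; within the scatter) and so does not separate the two compounds. The second methoxy group, added to the ring of compound 1, gives a 1.2-fold higher number from compound 1 to compound 3 (0.07 log units; within the scatter) and is just as unresolved. The earlier comparison changed the methoxy count by two groups at once, whereas these steps change it by one group at a time and show that neither single change can be told apart from the scatter, so this position tolerates either hydrogen or methoxy in this assay. Nothing measured here offers an explanation for this result.

The compounds shown carry only hydrogen or methoxy on this carbon, so it remains open whether a hydroxyl group, an amine or a chlorine atom there would give a step beyond the scatter. Also open, as far as these compounds go, is whether replacing the amine of the aminophenyl group, for instance with a carboxylic acid, would move the number further than these methoxy changes do.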